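Methyl Ester of the Second Acid: Another Expected Limit

This account rests on a few compounds, and the source may have more. Where it says the series, first, only, none or still open, it means among the compounds named here.

Compound 1, `O=C(O)c1cccc(CCCCCCC(=O)N2CCCC2)c1`, gives > 100000 nM in an assay on HEK293 cells for inhibition of N-acylethanolamine-hydrolyzing acid amidase (Rattus norvegicus), read by LC-MS, with a stated time of 30 min (a higher number here means a weaker inhibitor, a lower number a stronger inhibitor), which is a limit of the assay and not a number.
Compound 2, `O=C(O)c1ccc(CCCCCCC(=O)N2CCCC2)cc1`, gives > 100000 nM in this assay, again a limit of the assay.
Compound 3, `COC(=O)c1cccc(CCCCCCC(=O)N2CCCC2)c1`, gives > 100000 nM in this assay, also a limit of the assay.

All three measured compounds therefore share one feature: the limit of > 100000 nM in this assay, at which 3 of the 3 values shown sit. Compound 3 differs from compound 1 by methyl in place of hydrogen on an oxygen next to a carbonyl group. The step this made, a step that the two limits leave unreadable from compound 1 to compound 3, cannot be read, since both ends are limits.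

Compound 4, `COC(=O)c1ccc(CCCCCCC(=O)N2CCCC2)cc1`, is not yet measured. It differs from compound 2 by methyl in place of hydrogen on an oxygen next to a carbonyl group; the place lines of the two changes read identically, so this is the same change. How the core of compound 1 differs from the core of compound 2 is not broken down here.

Given that compound 1, compound 2 and compound 3 all sit at the limit, the expected step that the limit leaves unreadable from compound 2 to compound 4 is unreadable in the same way. Compound 4 is thus estimated at 200000 nM in this assay, most likely reported as a limit again.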

Compound 4, half-maximal inhibitory concentration: > 100000 nM
Compound 4: only a limit was reported (the forecaster's own chance of this, stated with the estimate: 85%); the middle value is on the limit's open side.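

Among these compounds, compound 2 and compound 4 both sit at a limit of the assay and not at a number, which leaves the step between them unreadable, and no new step emerges. All the compounds shown share this result: the limit of > 100000 nM in this assay, at which 4 of the 4 values shown sit.

What remains open is how strongly any of these compounds acts in this assay, and whether replacing carboxy with methoxycarbonyl changes that at all.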